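Alkyl groups on the aromatic nitrogen of the shared core

The compounds below may be only part of what the source reports. "The series", "measured", "known", "first", "only" and "open" are said of these compounds alone.

In an assay on Huh-7 cells for agonist activity at Bile acid receptor (Homo sapiens), read by a luciferase reporter (a lower number here means that less compound is needed, a higher number that more compound is needed for the effect), compound 1 `CC(C)c1onc(-c2c(Cl)cccc2Cl)c1COc1ccc(-c2nc3ccc(C(=O)O)cc3n2-c2ccc(F)cc2)cc1` gives 32.2 nM. Among the compounds with values here, compound 2 `CC(C)c1onc(-c2c(Cl)cccc2Cl)c1COc1ccc(-c2nc3ccc(C(=O)O)cc3n2C(C)C)cc1` gives 3.39 nM in this assay, the lowest of the two numbers so far; the only other measurement stands above it, as the step of a 9.5-fold lower number from compound 1 to compound 2 (0.98 log units; beyond the scatter) shows, a change on the same aromatic nitrogen that is beyond the scatter. Compound 3 `CC(C)c1onc(-c2c(Cl)cccc2Cl)c1COc1ccc(-c2nc3ccc(C(=O)O)cc3n2C2CCCC2)cc1` differs from compound 2 by cyclopentyl in place of isopropyl on an aromatic nitrogen. That single measured step is the only one that bears on this position, and it concerned the swap of an aromatic group for isopropyl, not a change from one alkyl to another. Compound 3 keeps an alkyl on the nitrogen, so the expected step of a 1.3-fold lower number from compound 2 to compound 3 (0.12 log units; within the scatter) is small, probably within the scatter, with at most a slight lean toward a lower number. For compound 3 the estimate in this assay is 2.6 nM, with a range from 0.9 nM to 8 nM.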

Compound 3, half-maximal effective concentration: 13.6 nM
Estimate against measurement, compound 3: 5.2-fold (0.72 log units) below; the measured number lies above the stated range.
By their numbers in this assay, from the lowest: compound 2; then compound 3; then compound 1.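

In this assay, the choice of alkyl group on the aromatic nitrogen matters, which the earlier step could not show because it compared only an aromatic group with isopropyl: cyclopentyl in place of isopropyl gives a change beyond the scatter (a 4.0-fold higher number from compound 2 to compound 3 (0.60 log units; beyond the scatter)). Cyclopentyl still retains part of the advantage over 4-fluorophenyl (a 2.4-fold lower number from compound 1 to compound 3 (0.37 log units; beyond the scatter)), so among these three groups it sits between isopropyl and 4-fluorophenyl, and having an alkyl group here does not by itself set the number. No evidence is available that bears on this difference between the two alkyl groups.

The compounds shown leave open where methyl, cyclopropyl or cyclobutyl on this nitrogen would fall relative to isopropyl and cyclopentyl. They also leave open whether a longer chain or a ring carrying an amine would follow the same order.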